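This account rests on a few compounds, and the source may have more. Where it says the series, first, only, none or still open, it means among the compounds named here.

Measured so far:
- compound 1 `O=C(NC(=S)N1CCc2c(OCCCCCOc3ccc(Cl)cc3)cccc21)c1ccc(C(F)(F)F)cc1` gives 32700 nM in an ADME assay on Huh-7 cells (Homo sapiens) for cytotoxicity; on this read-out higher numbers stand for lower toxicity in this test and lower numbers for higher toxicity in this test
- compound 2 `O=C(NC(=S)N1CCc2c(OCCCCCOc3ccc(Cl)cc3)cccc21)c1cccnc1` gives 11100 nM in this assay

For the measured compounds named here, compound 2 stands at the lower of the two numbers in this assay; its only neighbour is compound 1, and the single measured step, a 2.9-fold lower number from compound 1 to compound 2 (0.47 log units; beyond the scatter), is modest yet beyond the scatter. Compound 3 `O=S(=O)(NC(=S)N1CCc2c(OCCCCCOc3ccc(Cl)cc3)cccc21)c1ccccc1` has not yet been measured. It differs from compound 2 in one place: phenylsulfonyl in place of (pyridin-3-yl)carbonyl on an amide-type nitrogen. Going by the values given here, no measured step makes exactly this exchange. Among the compounds with values here, the one step known swaps the ring on the carbonyl carbon and leaves the carbonyl itself in place, whereas here the carbonyl gives way to a sulfonyl group and the ring loses its nitrogen; that step bears on the present one only loosely. Its modest size suggests a step of similar size in this assay, and with a carbon-only ring returning, as in compound 1 with its 32700 nM, a somewhat higher number seems more likely than a lower one, though with wide uncertainty. Compound 3 is therefore expected to give about 18000 nM, within 6000 nM to 55000 nM, an expected step of a 1.6-fold higher number from compound 2 to compound 3 (0.21 log units; within the scatter).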

Compound 3, half-maximal cytotoxic concentration: > 50000 nM
Compound 3 was reported as a limit; the forecaster's own chance of this, stated with the estimate: 10%; middle value at least 2.7-fold (0.44 log units) away from the limit.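

Until now, only the ring on the carbonyl carbon had changed, but here the whole unit on the amide-type nitrogen changes, with phenylsulfonyl in place of (pyridin-3-yl)carbonyl, and this assay records an at least 4.5-fold higher number from compound 2 to compound 3 (0.65 log units; beyond the scatter). Compound 3 is reported only as a limit, > 50000 nM, so its true number is not known and this step gives only a minimum size. The comparison with the carbonyl partner carrying 4-(trifluoromethyl)phenyl shows an at least 1.5-fold higher number from compound 1 to compound 3 (0.18 log units; that floor lies within the scatter), so the data set no firm order for this pair, and the sulfonyl group can be said to clearly raise the number only against the pyridin-3-yl carbonyl partner.

This exchange replaces the carbonyl with a sulfonyl and the pyridine ring with a carbon-only ring in a single move, so the two parts of the change cannot be separated, and nothing shown indicates which of them accounts for the step. On these data alone, a plain benzoyl group or a pyridin-3-ylsulfonyl group on the same nitrogen would change only one part at a time, and how either would read in this assay remains open.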